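A few compounds are considered here, and "the series" means these few. Any claim that something is new, unique, unknown or untested is made for them only; others in the source may bear on it.

Of the compounds shown here, two have so far been measured in a physicochemical assay for lipophilicity, measured as octanol-water partition; on this read-out lower numbers stand for lower lipophilicity and higher numbers for higher lipophilicity. Compound 1 (`CCCCCCCCc1cn(C/C=C(/C)CCC=C(C)C)nn1`) gives 6.92, while compound 2 (`CCCCCc1cn(C/C=C(\C)CCC=C(C)C)nn1`) gives 5.45. Compound 2 therefore holds the lower of the two numbers, and the gap between them lies beyond the usual scatter of repeated measurements.

The next compound to consider is compound 3 (`CCCCCc1cn(C/C=C(/C)CCC=C(C)C)nn1`), which has not yet been measured in this assay. Its relation to compound 2 is a narrow one: the two compounds have the same atoms and bonds and differ only in configuration as drawn: 1 of 1 stereo elements differ; a double bond is drawn E in compound 2 and Z in compound 3. Nothing leaves and nothing enters, so the change consists of that double bond alone.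

Among the compounds with values here, no pair of measured compounds shows what such a change in configuration does to this read-out, so the expectation has no measured step to lean on. With the atoms and bonds unchanged, the value of compound 2, 5.45, is the natural anchor, and no shift beyond the scatter is anticipated in either direction. The expected size of the step of no change at the digits printed from compound 2 to compound 3 (within the scatter) stays within that scatter. For compound 3 the estimated value is 5.45, with an expected range from 5.15 to 5.75.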

Compound 3, partition coefficient: 5.45
Beside the measured number, compound 3's estimate shows no gap at the digits printed; low and high end bracket the measured number.
By their numbers in this assay, from the lowest: compounds 2 and 3 (each within the scatter of the next); then compound 1.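

In this assay, within the data shown here, the step of no change at the digits printed from compound 2 to compound 3 (within the scatter) gives the first direct reading of what the double bond's configuration does at this position, and at this chain length the read-out does not separate the two drawn forms. The step can be tied to a single feature, since nothing else varies in this pair: the fact that compounds 2 and 3 differ only in the configuration as drawn. Among these compounds, the step of a number 1.47 log units lower from compound 1 to compound 3 (beyond the scatter) also gives the first comparison with compound 1 that differs in one place, hydrogen in place of propyl on a saturated chain carbon, five bonds along the chain from an aromatic carbon, so the large gap seen earlier can now be read against this chain change alone, with the configuration held the same.

The compounds shown leave open whether the configuration of the double bond would stay equally silent on the chain of compound 1, as the only pair that tests it carries the shorter chain. Among the compounds shown here, they also leave open how the read-out would respond to a longer chain, or to a chain bearing an amine or a carboxylic acid, as only two chain lengths, both plain hydrocarbon, appear here.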